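Methoxycarbonyl to Carboxy: Estimating Compound 3

This account rests on a few compounds, and the source may have more. Where it says the series, first, only, none or still open, it means among the compounds named here.

Compound 1 `CCCCCCNC(=O)c1cc(C#Cc2cc(OC)ccc2OC)ccc1OC` gives 56800 nM in a functional assay on UACC-62 cells (Homo sapiens) for antiproliferative activity; on this read-out higher numbers stand for weaker inhibition of growth and lower numbers for stronger inhibition of growth.
Compound 2 `COC(=O)c1cc(C#Cc2cc(OC)ccc2OC)ccc1OC` gives 29300 nM in this assay.

Among the two numbers measured so far, compound 2 has the lowest one. For the measured compounds named here, its only neighbour is compound 1, and the step between them, a 1.9-fold lower number from compound 1 to compound 2 (0.29 log units; within the scatter), is too small to count as a real difference in growth inhibition.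

Compound 3 `COc1ccc(OC)c(C#Cc2ccc(OC)c(C(=O)O)c2)c1` is the next compound. It differs from compound 2 in one place: hydrogen in place of methyl on an oxygen next to a carbonyl group. Going by the values given here, only one measured step exists to compare with, the exchange of hexylamino for methoxy on the carbonyl carbon, and that step was within the scatter. It touches the same carbonyl group but a different part of it, so it offers only a loose guide. Among the compounds with values here, the single measured exchange at this group changed nothing beyond the scatter, and the data hold no example of a hydrogen entering on an oxygen next to a carbonyl group. The expected step is therefore a 1.4-fold higher number from compound 2 to compound 3 (0.14 log units; within the scatter), meaning no real change in this assay. The estimate for compound 3 in this assay is 40000 nM, with a range from 15000 nM to 120000 nM.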

Compound 3, concentration for 50% growth inhibition: 22600 nM
For compound 3 the middle estimate is 1.8-fold (0.25 log units) above the measured one; measured number inside the range.
By their numbers in this assay, from the lowest: compounds 3, 2 and 1 (each within the scatter of the next, the first and the last beyond it).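

In this assay, hydrogen in place of methyl on an oxygen next to a carbonyl group, which turns methoxycarbonyl into carboxy, gives a 1.3-fold lower number from compound 2 to compound 3 (0.11 log units; within the scatter) and so makes no real difference to growth inhibition at this position. For the compounds shown here, the same compound also provides the first comparison in this small set that clears the scatter: swapping hexylamino for hydroxy at the same carbonyl gives a 2.5-fold lower number from compound 1 to compound 3 (0.40 log units; beyond the scatter) and counts as a modest gain in growth inhibition. Hexylamino, methoxy and hydroxy on this carbonyl carbon therefore form a short series in which each group cannot be told apart from the next, and only the two ends differ.

These three groups leave open whether a simple amide with no chain, an ethylamino group or a benzylamino group on the same carbonyl carbon would bring a larger step than any seen so far. Nothing available here explains the modest gap between the hexylamino and hydroxy compounds.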